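Replacing the Hydroxy-Methoxy Ring with a Bromophenyl Ring

The source may report more compounds than this note shows. Statements on the series, on what has been measured and on what is new or still open speak of the compounds shown alone.

Compound 1 `COc1ccc(C2=C(c3ccc(SC)cc3)CC3CCCN3C2=O)cc1O` gives 5000 nM in a functional assay on MCF-A cells (Homo sapiens) for cytotoxicity; on this read-out higher numbers stand for weaker inhibition of growth and lower numbers for stronger inhibition of growth. It stands level with compound 3 `COc1ccc(C2=C(c3ccc(SC)cc3)CC3CCCN3C2=O)cc1`, which gives 5000 nM, and together they carry the highest numbers of the three; compound 2 `COc1ccc(C2=C(c3ccc(SC)cc3)CC3CCCN3C2=O)cc1C` gives 400 nM and lies furthest from compound 1. Compound 4 `CSc1ccc(C2=C(c3ccc(Br)cc3)C(=O)N3CCCC3C2)cc1` differs from compound 1 by 4-bromophenyl in place of 3-hydroxy-4-methoxyphenyl on a double-bonded ring carbon. The step most directly related is no change at the digits printed from compound 1 to compound 3 (within the scatter), which likewise removes the hydroxy, while a 13-fold lower number from compound 1 to compound 2 (1.10 log units; beyond the scatter) shows that a change at that carbon can move the number strongly. For the measured compounds named here, no measured step exchanges the methoxy for bromine, so part of the change is uncharted. Compound 4 is therefore expected to show a 1.7-fold lower number from compound 1 to compound 4 (0.22 log units; within the scatter), a shift within the scatter. The value of compound 4 is estimated at 3000 nM, within 500 nM to 20000 nM.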

Compound 4, concentration for 50% growth inhibition: 8000 nM
Compound 4: the middle estimate sits 2.7-fold (0.43 log units) below what was measured; the measured number falls inside the stated range.
By their numbers in this assay, from the lowest: compound 2; then compounds 1, 3 and 4 (each within the scatter of the next).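

In this assay, the full ring exchange stays within the scatter (a 1.6-fold higher number from compound 1 to compound 4 (0.20 log units; within the scatter)), and so does bromo in place of methoxy alone (a 1.6-fold higher number from compound 3 to compound 4 (0.20 log units; within the scatter)), so at this position the methoxy can give way to bromo without a readable change. The methyl-bearing ring of compound 2 remains apart (a 20-fold higher number from compound 2 to compound 4 (1.30 log units; beyond the scatter)). No evidence on the cause of this is at hand. The compounds shown leave open whether an ethyl group or an amine in place of the methyl of compound 2 would keep its lower number, and whether bromo in place of methoxy would remain without effect with that methyl present.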